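The source may report more compounds than this note shows. Statements on the series, on what has been measured and on what is new or still open speak of the compounds shown alone.

Compound 2, `COc1cc(-c2nn(-c3cccc(NC(=O)Nc4ccc(Cl)c(C(F)(F)F)c4)c3)cc2-c2ccncc2)ccc1Cl`, and compound 1, `COc1cc(-c2nn(-c3cccc(NC(=O)Nc4cccc(C(F)(F)F)c4)c3)cc2-c2ccncc2)ccc1Cl`, share a core and differ only on one outer ring. In a functional assay on SF-539 cells (Homo sapiens) for inhibition, read by sulforhodamine B assay, with a stated time of 48 h (on this read-out higher numbers stand for weaker inhibition of growth and lower numbers for stronger inhibition of growth), compound 2 gives 1650 nM, the higher of the two numbers; compound 1 gives 890 nM, and the step of a 1.9-fold higher number from compound 1 to compound 2 (0.27 log units; within the scatter) lies within the scatter. Compound 3, `COc1cc(-c2nn(-c3cccc(NC(=O)c4ccccc4)c3)cc2-c2ccncc2)ccc1Cl`, carries a larger change: phenyl in place of (4-chloro-3-(trifluoromethyl)phenyl)amino on a carbonyl carbon. Among the measured compounds shown here, no measured step removes that whole group, so the only step so far bears on it weakly. Compound 3 is therefore expected at 5000 nM, between 1500 nM and 20000 nM, a step of a 3.0-fold higher number from compound 2 to compound 3 (0.48 log units; beyond the scatter) taken as an estimate only.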

Compound 3, concentration for 50% growth inhibition: 387 nM
Estimate against measurement, compound 3: 13-fold (1.11 log units) above, outside the stated range (below it).
By their numbers in this assay, from the lowest: compound 3; then compounds 1 and 2 (each within the scatter of the next).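

In this assay, the whole (4-chloro-3-(trifluoromethyl)phenyl)amino group can give way to phenyl on the carbonyl carbon without any loss of growth inhibition: that change yields a 4.3-fold lower number from compound 2 to compound 3 (0.63 log units; beyond the scatter) and the matching change from (3-(trifluoromethyl)phenyl)amino yields a 2.3-fold lower number from compound 1 to compound 3 (0.36 log units; beyond the scatter) as well. Unlike the chloro step, both of these modest steps clear the scatter, so this position tolerates a change of the whole group. No measurement here explains the gain. Still open, as far as these compounds go, is whether a further group on this phenyl, such as methoxy or an amine, would lower the number further, and whether a cyclohexyl ring could replace the phenyl.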